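Chalcone boronates: the aryl ketone variations

The source may hold more compounds than are shown below. What is called first, only, known or untested is meant among the compounds shown, and "the series" means these compounds.

Measured so far:
compound 1, `O=C(/C=C/c1ccc2c(c1)B(O)OC2)c1ccccc1`, 2300 nM
compound 2, `O=C(/C=C/c1ccc2c(c1)B(O)OC2)c1ccc(O)cc1`, 25600 nM

For the measured compounds named here, in a functional assay on MDA-MB-231 cells (Homo sapiens) for cytotoxicity, read by MTT assay, with a stated time of 48 h (on this read-out lower numbers stand for stronger inhibition and higher numbers for weaker inhibition), compound 2 gives the highest of the two numbers in hand; its nearest neighbour is compound 1, and the step of an 11-fold higher number from compound 1 to compound 2 (1.05 log units; beyond the scatter) is the only measured change. Compound 3, `O=C(/C=C/c1ccc2c(c1)B(O)OC2)c1ccccc1F`, is not yet measured. The change from compound 2 to compound 3 is 2-fluorophenyl in place of 4-hydroxyphenyl on a carbonyl carbon. Going by the values given here, the hydroxy group that went in from compound 1 to compound 2 leaves again here, and the single measured step bears on that part of the change: compound 1 without the hydroxy gave 2300 nM, compound 2 with it gave 25600 nM. Among the compounds with values here, no measured step speaks to the fluorine that enters. The expectation is therefore a return toward the number of compound 1, a step of about an 8.5-fold lower number from compound 2 to compound 3 (0.93 log units; beyond the scatter) downward in this assay . Compound 3 is estimated at 3000 nM, with a range from 1000 nM to 10000 nM.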

Compound 3, half-maximal inhibitory concentration: 2200 nM
Beside the measured number, compound 3's estimate is 1.4-fold (0.13 log units) above it; the range from low to high includes it.
By their numbers in this assay, from the lowest: compounds 3 and 1 (each within the scatter of the next); then compound 2.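

In this assay, fluoro in place of hydrogen on an aromatic carbon gives a 1.0-fold lower number from compound 1 to compound 3 (0.02 log units; within the scatter), so the ketone aryl group accepts this fluorine with no difference beyond the scatter. The exchange of 4-hydroxyphenyl for 2-fluorophenyl on a carbonyl carbon gives a 12-fold lower number from compound 2 to compound 3 (1.07 log units; beyond the scatter), which leaves compound 2 as the only one of the three with a hydroxy group and the only one set apart by a large step. No measurement at hand explains the difference between these aryl groups.

Open, as far as these compounds go, is whether a methoxy group or an amine in the place of the hydroxy would give a number like that of compound 2 or like that of compound 3. Also open, from the compounds shown here alone, is whether chloro or a second fluoro would stay within the scatter of compound 3.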